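Lengthening the hydroxyalkyl sulfonyl chain by one carbon

The compounds below may be only part of what the source reports. "The series", "measured", "known", "first", "only" and "open" are said of these compounds alone.

Compound 1 `CCCc1cnc(N2CCC(C3(C)Cc4cc(C5=CCN(S(=O)(=O)CCC)CC5)ccc4O3)CC2)nc1`: 70 nM
Compound 2 `CCCc1cnc(N2CCC(C3(C)Cc4cc(C5=CCN(S(=O)(=O)CCCO)CC5)ccc4O3)CC2)nc1`: 78 nM

In a functional assay on HEK293 cells for agonist activity at Glucose-dependent insulinotropic receptor (Homo sapiens), read by cAMP accumulation, with a stated time of 60 min (a lower number here means that less compound is needed, a higher number that more compound is needed for the effect), compound 1 gives 70 nM and compound 2 gives 78 nM. Among the compounds with values here, the two values lie within the scatter of each other; the only measured step, a 1.1-fold higher number from compound 1 to compound 2 (0.05 log units; within the scatter), records that adding the hydroxy group to the chain on the sulfonyl sulfur left the number essentially unchanged.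

Compound 3 `CCCc1cnc(N2CCC(C3(C)Cc4cc(C5=CCN(S(=O)(=O)CCCCO)CC5)ccc4O3)CC2)nc1` carries the change (hydroxymethyl in place of hydroxy on a saturated chain carbon, three bonds along the chain from a sulfonyl sulfur). Within the data shown here, the one measured step bears on it only loosely, since it concerns the hydroxy group itself rather than the length of the chain that holds it, but it shows the assay tolerating a modification at this position without a shift beyond the scatter. No change beyond the scatter is therefore expected for compound 3, and its step of a 1.0-fold higher number from compound 2 to compound 3 (0.01 log units; within the scatter) is estimated as flat. Compound 3 is expected to give about 80 nM in this assay, within 40 nM to 160 nM.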

Compound 3, half-maximal effective concentration: 28 nM
For compound 3 the middle estimate is 2.9-fold (0.46 log units) above the measured one, outside the stated range (below it).
By their numbers in this assay, from the lowest: compound 3; then compounds 1 and 2 (each within the scatter of the next).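

Within the data shown here, the sulfonyl chain proves more sensitive to length than the earlier pair suggested: in this assay, going from 3-hydroxypropyl to 4-hydroxybutyl gives a 2.8-fold lower number from compound 2 to compound 3 (0.44 log units; beyond the scatter) and is the first change here to pass beyond the scatter. Adding the hydroxy group to the shorter chain had moved nothing beyond the scatter, whereas hydroxymethyl in place of hydrogen at the same carbon gives a 2.5-fold lower number from compound 1 to compound 3 (0.40 log units; beyond the scatter), so at this position the added carbon separates the result from both earlier compounds. Nothing available here accounts for this difference.

The compounds shown leave open whether a longer chain, such as 5-hydroxypentyl, would extend the shift or reverse it. They also leave open whether a plain butyl chain would do the same, and whether an amine or a carboxylic acid could stand in place of the hydroxy group at the end of the chain.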